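The compounds below may be only part of what the source reports. "The series", "measured", "known", "first", "only" and "open" are said of these compounds alone.

Compound 1, `COCc1ccc(-c2ccc3nnc(C(N)=O)c(N[C@@H](C)C4CCOCC4)c3c2)cn1`, is the starting point. In an ADME assay on cells (Hepatocyte, Rattus norvegicus) for metabolic stability, read by HPLC, with a stated time of 30 min, tested at 1 uM (a higher number here means faster removal of the compound, a lower number slower removal), compound 1 gives 5.6 uL/min, the second highest of the three numbers recorded. Its nearest neighbour is compound 2, `COCc1ccc(-c2ccc3nnc(C(N)=O)c(N[C@@H](C)c4ccn(C)n4)c3c2)cn1`, which gives 4.9 uL/min; the step of a 1.1-fold lower number from compound 1 to compound 2 (0.06 log units; within the scatter). Compound 3, `COCc1ccc(-c2ccc3nnc(C(N)=O)c(N[C@@H](C)c4nn(C)cc4C)c3c2)cn1`, gives 18 uL/min, and the step of a 3.2-fold higher number from compound 1 to compound 3 (0.51 log units; beyond the scatter) is the larger of the two; between the pyrazole pair, a 3.7-fold higher number from compound 2 to compound 3 (0.57 log units; beyond the scatter).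

The unmeasured compound 4, `C[C@H](Nc1c(C(N)=O)nnc2ccc(-c3ccc(OCCCN4CCCC4)nc3)cc12)C1CCOCC1`, differs from compound 1 at the other end of the molecule: 3-(pyrrolidin-1-yl)propoxy in place of methoxymethyl on an aromatic carbon. Going by the values given here, none of the measured steps touches this position; all three alter the group on the saturated chain carbon bound to the ring nitrogen. So nothing recorded here bears directly on the change, and the only guidance is that the largest step seen so far, from compound 1 to compound 3, was modest. Compound 4 is therefore estimated to sit near compound 1, with a wide range, the expected step being a 1.4-fold higher number from compound 1 to compound 4 (0.15 log units; within the scatter). The estimate for compound 4 is 8 uL/min, between 3 uL/min and 25 uL/min.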

Compound 4, intrinsic clearance in a liver preparation (reported as CLH), per the amount of preparation that the assay uses: 1.9 uL/min
Compound 4: middle estimate off by 4.2-fold (0.62 log units), on the high side; measured number below the stated range.
By their numbers in this assay, from the lowest: compound 4; then compounds 2 and 1 (each within the scatter of the next); then compound 3.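

Going by these compounds alone, this is the first reading at this position, on an aromatic carbon next to the ring nitrogen, and in this assay the exchange gives a 2.9-fold lower number from compound 1 to compound 4 (0.47 log units; beyond the scatter) with the oxan-4-yl side of the molecule held constant. The position is therefore not silent in this assay, and the larger 3-(pyrrolidin-1-yl)propoxy group, with its five-membered non-aromatic ring, lowers the number rather than raising it. No measurement at hand accounts for this step.

The compounds shown leave open whether the step belongs to the pyrrolidine ring or to the propoxy chain, which a plain propoxy group or a morpholine at the chain end would help to separate. Also open, going by these compounds, is whether the same exchange would act alike on the pyrazole-bearing compound 2 and compound 3.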